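Trading a butyl end for vinyl on the chain

This account rests on a few compounds, and the source may have more. Where it says the series, first, only, none or still open, it means among the compounds named here.

Three compounds share one core and differ only in the length of a saturated chain. In a functional assay, read by fluorescence and spectrophotometry, with a stated time of 1 h (a higher number here means that more compound is needed for the effect, a lower number that less compound is needed), compound 1 (`CCCCCCCCCCCCS(=O)(=O)/C=C/c1ccc(O)c(O)c1`) gives 8500 nM while compound 2 (`CCCCCCCCCCCS(=O)(=O)/C=C/c1ccc(O)c(O)c1`) gives 11400 nM and compound 3 (`CCCCCCCCCS(=O)(=O)/C=C/c1ccc(O)c(O)c1`) gives 7700 nM as its value. Compound 3 therefore stands within the scatter of both others (a 1.1-fold lower number from compound 1 to compound 3 (0.04 log units; within the scatter); a 1.5-fold lower number from compound 2 to compound 3 (0.17 log units; within the scatter)). The remaining step is also small (a 1.3-fold higher number from compound 1 to compound 2 (0.13 log units; within the scatter)).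

Compound 4 (`C=CCCCCCS(=O)(=O)/C=C/c1ccc(O)c(O)c1`) departs from compound 3 by one further change (vinyl in place of butyl on a saturated chain carbon, five bonds along the chain from a sulfonyl sulfur): vinyl in place of butyl on a saturated chain carbon, five bonds along the chain from a sulfonyl sulfur. The three measured steps bear on this change only in part. Going by these compounds, they remove saturated chain carbons, but none of them reaches this place on the chain and none introduces a double bond, so the vinyl group is untested. All three stayed within the scatter, so no step beyond the scatter is expected in this assay for this change, although the range must stay wide. The estimated step is a 1.0-fold higher number from compound 3 to compound 4 (0.02 log units; within the scatter) on this reasoning. Compound 4 is expected at about 8000 nM as a central estimate. Its estimated range runs from 3500 nM to 19000 nM for repeated measurements.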

Compound 4, half-maximal effective concentration: 7100 nM
The estimate for compound 4 lay 1.1-fold (0.05 log units) above the measured number; the range from low to high includes it.
By their numbers in this assay, from the lowest: compounds 4, 3, 1 and 2 (each within the scatter of the next).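

In this assay, vinyl in place of butyl, on a saturated chain carbon five bonds along the chain from a sulfonyl sulfur, gives a 1.1-fold lower number from compound 3 to compound 4 (0.04 log units; within the scatter). For the compounds shown here, this is the first evidence at this place on the chain: a double bond outside aromatic rings can stand at the chain end, on a shorter chain, without a step that rises above the scatter. Set against the two longer chains, the picture is the same, with vinyl in place of hexyl giving a 1.6-fold lower number from compound 2 to compound 4 (0.21 log units; within the scatter) and vinyl in place of heptyl giving a 1.2-fold lower number from compound 1 to compound 4 (0.08 log units; within the scatter), so across all four compounds neither the chain length nor the double bond separates one number from another in this assay.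

Still open, going by these compounds, is whether this flat picture lasts once the chain end carries something other than plain carbon and hydrogen, such as an amine or a carboxylic acid, or once the chain is cut much shorter, to an ethyl group, for example. Nothing shown here accounts for how little these chain changes move the number.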